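Replacing the methylsulfonyl group on the ether oxygen of compound 1

The compounds below may be only part of what the source reports. "The series", "measured", "known", "first", "only" and "open" are said of these compounds alone.

Compound 1 `CS(=O)(=O)Oc1ccccc1Cc1cnc(N)nc1N` gives 22900 nM in an assay for inhibition of Dihydrofolate reductase (Gallus gallus) (a lower number here means a stronger inhibitor, a higher number a weaker inhibitor), the highest of the three numbers. Compound 3 `C=CCOc1ccccc1Cc1cnc(N)nc1N` sits within the scatter of it, at 21400 nM, while compound 2 `CCCCCCOc1ccccc1Cc1cnc(N)nc1N` gives 7940 nM. Compound 4 `NC(=O)COc1ccccc1Cc1cnc(N)nc1N` differs from compound 1 by carbamoylmethyl in place of methylsulfonyl on an oxygen on an aromatic ring. Two measured steps change the same group on the same oxygen: a 2.9-fold lower number from compound 1 to compound 2 (0.46 log units; beyond the scatter) and a 1.1-fold lower number from compound 1 to compound 3 (0.03 log units; within the scatter). A small replacement left the number unchanged, and only the hexyl chain moved it modestly. The carbamoylmethyl group is likewise small, so the step of a 1.4-fold lower number from compound 1 to compound 4 (0.16 log units; within the scatter) is expected to stay near the scatter. Compound 4 is therefore estimated at 16000 nM, between 6000 nM and 40000 nM.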

Compound 4, inhibition constant: 33900 nM
For compound 4 the middle estimate is 2.1-fold (0.33 log units) below the measured one; the range from low to high includes it.
By their numbers in this assay, from the lowest: compound 2; then compounds 3, 1 and 4 (each within the scatter of the next).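

With carbamoylmethyl on the oxygen, the number stays level with those of the earlier small groups (a 1.5-fold higher number from compound 1 to compound 4 (0.17 log units; within the scatter); a 1.6-fold higher number from compound 3 to compound 4 (0.20 log units; within the scatter)), even though this group brings a hydrogen-bond donor that methylsulfonyl lacks. The hexyl chain of compound 2 remains apart from this group of three (a 4.3-fold higher number from compound 2 to compound 4 (0.63 log units; beyond the scatter)). Nothing available explains why the hexyl chain alone stands apart. Still open, as far as these compounds go, is whether a longer chain than hexyl would lower the number further, and how an amine or a carboxylic acid on the saturated chain carbon bound to the oxygen would compare.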